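From 4-Methoxyphenyl to 3-Bromophenyl on a Shared Core

The source may hold more compounds than are shown below. What is called first, only, known or untested is meant among the compounds shown, and "the series" means these compounds.

In an ADME assay on HEK293 cells (Homo sapiens) for cytotoxicity, read by MTT assay, with a stated time of 72 h (a higher number here means a weaker inhibitor, a lower number a stronger inhibitor), compound 1 `O=C(CN1CCN(C(=O)c2ccccc2)CC1)N1CCN(CCCc2c[nH]c3ccccc23)CC1` gives > 200000 nM as a limit of the assay and not a number. Compound 2 `COc1ccc(C(=O)N2CCN(CC(=O)N3CCN(CCCc4c[nH]c5ccccc45)CC3)CC2)cc1` gives 156000 nM and stands as the higher of the two actual numbers, with compound 3 `O=C(CN1CCN(C(=O)c2ccc(Br)cc2)CC1)N1CCN(CCCc2c[nH]c3ccccc23)CC1` at 71900 nM as its nearest neighbour. Compound 4 `O=C(CN1CCN(C(=O)c2cccc(Br)c2)CC1)N1CCN(CCCc2c[nH]c3ccccc23)CC1` departs from compound 2 by the change 3-bromophenyl in place of 4-methoxyphenyl on a carbonyl carbon in which 3-bromophenyl stands in place of 4-methoxyphenyl on a carbonyl carbon. The closest guide is a 2.2-fold lower number from compound 2 to compound 3 (0.34 log units; beyond the scatter) for bromo in place of methoxy on an aromatic carbon. Bromo in place of hydrogen points the same way with an at least 2.7-fold lower number from compound 1 to compound 3 (0.44 log units; beyond the scatter) while methoxy in place of hydrogen gives an at least 1.2-fold lower number from compound 1 to compound 2 (0.10 log units; that floor lies within the scatter) as its step. Among the measured compounds shown here, no measured compound yet carries the 3-bromophenyl group, so this guide is indirect. On that basis a modest fall is expected, and the estimated step in this assay is a 2.1-fold lower number from compound 2 to compound 4 (0.32 log units; beyond the scatter) for the new group. For compound 4 the estimated value is 75000 nM with 35000 nM to 150000 nM as the expected range.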

Compound 4, half-maximal inhibitory concentration: 80700 nM
For compound 4 the middle estimate is 1.1-fold (0.03 log units) below the measured one; measured number inside the range.
By their numbers in this assay, from the lowest: compounds 3, 4 and 2 (each within the scatter of the next, the first and the last beyond it). At a limit, above all of these: compound 1.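

Placing the bromine as 3-bromophenyl in place of 4-bromophenyl on a carbonyl carbon gives a 1.1-fold higher number from compound 3 to compound 4 (0.05 log units; within the scatter) in this assay, so the two bromophenyl compounds cannot be told apart here. The replacement of 4-methoxyphenyl by 3-bromophenyl gives a 1.9-fold lower number from compound 2 to compound 4 (0.29 log units; within the scatter), whereas the earlier replacement by 4-bromophenyl gave a 2.2-fold lower number from compound 2 to compound 3 (0.34 log units; beyond the scatter), so a separation from the methoxy compound beyond the scatter holds for only one of the two bromo groups. The remaining step, an at least 2.4-fold lower number from compound 1 to compound 4 (0.39 log units; beyond the scatter), is only a floor, since the value for compound 1 is a limit of the assay and not a number: the limit of > 200000 nM in this assay, at which 1 of the 4 values shown sits.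

A 3-methoxyphenyl group would show whether the methoxy compound reads the same at this other ring position. On these data alone, how a 3-chlorophenyl group or a phenyl ring carrying an amine or a carboxylic acid would read remains open.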